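Aryl piperazine variation: from compound 3 to compound 4

The compounds below may be only part of what the source reports. "The series", "measured", "known", "first", "only" and "open" are said of these compounds alone.

Three compounds of one shared core differ only in the aryl group on an amine nitrogen in a ring. Compound 1 `Nc1scc(CN2CCN(c3ccc(Cl)cc3Cl)CC2)c1C(=O)c1ccc(Cl)cc1` gives -74% in a functional assay on CHO cells with adenosine receptor A1 (Homo sapiens) as the target, read by cAMP accumulation and immunoassay, with a stated time of 6 min, tested at 10 uM; on this read-out lower numbers stand for a stronger effect and higher numbers for a weaker effect at the one concentration tested. Compound 2 `Nc1scc(CN2CCN(c3ccc(Cl)c(C(F)(F)F)c3)CC2)c1C(=O)c1ccc(Cl)cc1` gives -60%, and compound 3 `Nc1scc(CN2CCN(c3cccc(F)c3)CC2)c1C(=O)c1ccc(Cl)cc1` gives -82%. Compound 3 sits at the low end of these three numbers: the step of a number 8 percentage points lower from compound 1 to compound 3 (within the scatter) is within the scatter, whereas the step of a number 22 percentage points lower from compound 2 to compound 3 (beyond the scatter) is beyond it; the step of a number 14 percentage points higher from compound 1 to compound 2 (beyond the scatter) separates the other two.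

Compound 4 `Nc1scc(CN2CCN(c3c(F)cccc3F)CC2)c1C(=O)c1ccc(Cl)cc1` has not been measured. It differs from compound 3 by 2,6-difluorophenyl in place of 3-fluorophenyl on an amine nitrogen in a ring. For the measured compounds named here, no measured step places two fluorines on this ring, so the 2,6-difluorophenyl group is untested; the two steps that bear on it are those ending at compound 3, which ran from modest to within the scatter, and all three aryl groups land within a narrow band. Hence in this assay the expected step of a number 8 percentage points higher from compound 3 to compound 4 (within the scatter) is small, likely within the scatter, with a slight lean toward a higher number. Compound 4 is estimated at -74%, between -90% and -55%.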

Compound 4, a percentage reported as activity, at one concentration (the size of the read-out at that concentration, not a potency): -80%
For compound 4 the middle estimate is 6 percentage points above the measured one; measured number inside the range.
By their numbers in this assay, from the lowest: compounds 3, 4 and 1 (each within the scatter of the next); then compound 2.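

In this assay, the 2,6-difluorophenyl group on the amine nitrogen in the ring gives no separation from the 3-fluorophenyl group, with a number 2 percentage points higher from compound 3 to compound 4 (within the scatter), so a second fluorine on the aryl ring leaves the read-out unresolved from that of the single fluorine. For the compounds shown here, the same holds against the 2,4-dichlorophenyl group, with a number 6 percentage points lower from compound 1 to compound 4 (within the scatter), whereas a number 20 percentage points lower from compound 2 to compound 4 (beyond the scatter) leaves the 4-chloro-3-(trifluoromethyl)phenyl group as the only aryl group here that stands apart from all the others by more than the scatter. Nothing at hand explains how these aryl groups rank.

The compounds shown carry only halogens and trifluoromethyl on a phenyl ring, so a methoxy group, a nitrile or a pyridyl ring in place of the phenyl remains open. On these data alone, with one concentration per compound, the potency of this series also remains open.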